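Extending the Methyl of Compound 2 to 2-Hydroxyethyl

The source may report more compounds than this note shows. Statements on the series, on what has been measured and on what is new or still open speak of the compounds shown alone.

In a functional assay on MIA PaCa-2 cells (Homo sapiens) for inhibition, read by MTT assay, with a stated time of 72 h, tested at 50 uM (a higher number here means more inhibition of growth at the concentration tested, a lower number less inhibition of growth), compound 1 (`C=CCc1ccc(OCc2cn(-c3cccc([N+](=O)[O-])c3)nn2)c(O)c1`) gives 58.8%. Compound 2 (`C=CCc1cc(O)c(O)c(CN2CCC(C)CC2)c1`) gives 90.6%, the higher of the two numbers and beyond the scatter from compound 1. Compound 3 (`C=CCc1cc(O)c(O)c(CN2CCC(CCO)CC2)c1`) differs from compound 2 by hydroxymethyl in place of hydrogen on a saturated chain carbon bound to a saturated ring carbon, so that methyl becomes 2-hydroxyethyl. Among the measured compounds shown here, no measured pair shows the effect of this change. The expected change is a number 10.6 percentage points lower from compound 2 to compound 3 (beyond the scatter), a modest fall about the size of the scatter. For compound 3 the estimated value is 80%, with an expected range of 58% to 95%.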

Compound 3, percent growth inhibition at one concentration: 71.8%
For compound 3 the middle estimate is 8.2 percentage points above the measured one; low and high end bracket the measured number.
By their numbers in this assay, from the lowest: compound 1; then compound 3; then compound 2.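

Changing methyl to 2-hydroxyethyl on a saturated chain carbon bound to a saturated ring carbon brings a number 18.8 percentage points lower from compound 2 to compound 3 (beyond the scatter) in this assay and so shows that this position responds to the change. Compound 3 still gives 71.8% in this assay and thus retains substantial inhibition of growth with the larger group in place. No measurement here accounts for the fall.

Whether the added length or the hydroxyl group accounts for the step remains open. An ethyl or 2-aminoethyl group in place of the methyl would help separate the two.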